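A few compounds are considered here, and "the series" means these few. Any claim that something is new, unique, unknown or untested is made for them only; others in the source may bear on it.

Measured compounds:
- compound 1, `CC1(c2ccccc2)CC(=O)C(C(CC(=O)c2ccc(-c3ccc(Br)cc3)cc2)c2ccccc2)=C(O)O1`: 5690 nM
- compound 2, `CCC1(c2ccccc2)CC(=O)C(C(CC(=O)c2ccc(-c3ccc(Br)cc3)cc2)c2ccccc2)=C(O)O1`: 5740 nM

Of the compounds shown here, two have been tested in a functional assay on SK-OV-3 cells (Homo sapiens) for inhibition, with a stated time of 72 h; on this read-out lower numbers stand for stronger inhibition and higher numbers for weaker inhibition. Compound 1 gives 5690 nM, and compound 2 gives 5740 nM. The two differ in one place only, a methyl in place of hydrogen on a saturated chain carbon bound to a saturated ring carbon, and the step is a 1.0-fold higher number from compound 1 to compound 2 (0.00 log units; within the scatter). On these numbers compound 2 sits next to compound 1 with no separation worth reading.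

Compound 3, `CCCC1(c2ccccc2)CC(=O)C(C(CC(=O)c2ccc(-c3ccc(Br)cc3)cc2)c2ccccc2)=C(O)O1`, has not been measured. It differs from compound 2 by methyl in place of hydrogen on a saturated chain carbon, two bonds along the chain from a saturated ring carbon. Among the measured compounds shown here, only one measured step bears on this change, the step from compound 1 to compound 2, which was a 1.0-fold higher number from compound 1 to compound 2 (0.00 log units; within the scatter). Since that step was a 1.0-fold higher number from compound 1 to compound 2 (0.00 log units; within the scatter), the expectation for compound 3 is a 1.0-fold higher number from compound 2 to compound 3 (0.00 log units; within the scatter), with no shift beyond the scatter in either direction. Compound 3 is therefore estimated at 5800 nM, within a range of 2900 nM to 11600 nM.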

Compound 3, half-maximal inhibitory concentration: > 10000 nM
Compound 3: no number, only a limit; the forecaster's own chance of this, stated with the estimate: 5%; at least 1.7-fold (0.23 log units) between middle value and limit.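

In this assay compound 3 gives > 10000 nM, which is a limit of the assay and not a number. Going from ethyl to propyl gives an at least 1.7-fold higher number from compound 2 to compound 3 (0.24 log units; that floor lies within the scatter), and going from methyl to propyl gives an at least 1.7-fold higher number from compound 1 to compound 3 (0.24 log units; that floor lies within the scatter); both are floors rather than measured sizes, so the true size of each step remains unknown. Unlike the methyl to ethyl change, which showed no separation, this one ends in a result that cannot be placed on the scale, and a loss of inhibition beyond the scatter is possible but not shown: the limit of > 10000 nM in this assay, at which 1 of the 3 values shown sits.

The compounds shown leave open how far compound 3 really lies from the other two. They also leave open whether a butyl chain or an aminopropyl chain in place of the propyl would give a number in this assay.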